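Thioether-linked coumarin series: ester for nitrile at the benzyl ring

A few compounds are considered here, and "the series" means these few. Any claim that something is new, unique, unknown or untested is made for them only; others in the source may bear on it.

The series shares one core, seen in compound 1 `Cc1cc(=O)oc2cc(SCc3cccnc3)ccc12`, compound 2 `Cc1cc(=O)oc2cc(SCc3cccc(C(F)(F)F)c3)ccc12` and compound 3 `Cc1cc(=O)oc2cc(SCc3cccc(C#N)c3)ccc12`, with a pyridylmethyl or substituted benzyl thioether. In a functional assay on KBVIN cells (Homo sapiens) for antiproliferative activity, read by sulforhodamine B assay, with a stated time of 72 h (a lower number here means a stronger inhibitor of growth, a higher number a weaker inhibitor of growth), compound 1 reports only a limit, > 35200 nM. Compound 2 likewise reports a limit in this assay, > 28500 nM. Compound 3 also reports a limit in this assay, > 32500 nM. Among the measured compounds shown here, the one single-point step among the measured compounds, a step that the two limits leave unreadable from compound 2 to compound 3, cannot be sized, since both ends sit at limits the limit of > 28500 nM in this assay, at which 1 of the 3 values shown sits, and (the limit of > 32500 nM in this assay, at which 1 of the 3 values shown sits), as does the remaining value (the limit of > 35200 nM in this assay, at which 1 of the 3 values shown sits). Compound 3 therefore stands at a limit alongside the other two, with no ordering readable among them.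

Compound 4 `COC(=O)c1cccc(CSc2ccc3c(C)cc(=O)oc3c2)c1` differs from compound 3 by methoxycarbonyl in place of cyano on an aromatic carbon. For the measured compounds named here, no measured step covers an ester for a nitrile; the only adjacent evidence is the unreadable step from compound 2 to compound 3, where swapping one meta substituent for another left the compound at a limit. Nothing shown therefore supports a move beyond the scatter, and the expected step is a step that the limit leaves unreadable from compound 3 to compound 4, i.e. none readable. Compound 4 is expected to remain at or near the limit, estimated at 40000 nM with a range of 10000 nM to 100000 nM, most likely reported as a limit again.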

Compound 4, concentration for 50% growth inhibition: 5410 nM
Compound 4: middle estimate off by 7.4-fold (0.87 log units), on the high side; measured number below the stated range.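

Among the compounds shown here, compound 4 is the first compound to give a measured number rather than a limit in this assay, so this position on the benzyl ring, meta to a large group, now shows a readable effect: methoxycarbonyl in place of cyano gives an at least 6.0-fold lower number from compound 3 to compound 4 (0.77 log units; beyond the scatter). Methoxycarbonyl in place of trifluoromethyl at the same position gives an at least 5.2-fold lower number from compound 2 to compound 4 (0.72 log units; beyond the scatter), so the step holds against both groups tested there, and each size is only a minimum because compound 2 and compound 3 stand at limits, while the step between those two still cannot be read. No measurement shown gives a reason for either step.

The compounds shown leave open which part of the methoxycarbonyl group carries the effect, and a carboxylic acid, a primary amide or an ethyl ester at this position would help separate the carbonyl from the methyl end. They also leave open whether the same ester keeps the effect on a pyridine ring like that of compound 1.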